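Methyl for trifluoromethyl on the pyrazole amide

The source may report more compounds than this note shows. Statements on the series, on what has been measured and on what is new or still open speak of the compounds shown alone.

Measured compounds:
compound 1 `CC1(C)Cc2c(sc(NC(=O)[C@@H](O)C(C)(C)C)c2C(N)=O)C(C)(C)O1`, 421 nM
compound 2 `CC1(C)Cc2c(sc(NC(=O)c3cc(C(F)(F)F)n[nH]3)c2C(N)=O)C(C)(C)O1`, 130 nM

In an assay on cells for positive allosteric modulation of Cystic fibrosis transmembrane conductance regulator variant G551D (Homo sapiens), with stated times of 10 min and 2 min, in the presence of a further agent that is not named here (a lower number here means that less compound is needed, a higher number that more compound is needed for the effect), compound 1 gives 421 nM, and compound 2 gives 130 nM. For the measured compounds named here, the one measured step, a 3.2-fold lower number from compound 1 to compound 2 (0.51 log units; beyond the scatter), puts compound 2 at the lower of the two numbers. Compound 3 `Cc1cc(C(=O)Nc2sc3c(c2C(N)=O)CC(C)(C)OC3(C)C)[nH]n1` differs from compound 2 by methyl in place of trifluoromethyl on an aromatic carbon. Going by the values given here, no measured pair shows this change; the only step in hand, a 3.2-fold lower number from compound 1 to compound 2 (0.51 log units; beyond the scatter), exchanges the whole acyl group and speaks to it only loosely. With the pyrazole kept and only its substituent altered, a step no larger than the usual scatter is expected, with a mild lean toward a higher number. Compound 3 is therefore estimated at 250 nM in this assay, within 80 nM to 800 nM, which means an expected step of a 1.9-fold higher number from compound 2 to compound 3 (0.28 log units; within the scatter).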

Compound 3, half-maximal effective concentration: 590 nM
Beside the measured number, compound 3's estimate is 2.4-fold (0.37 log units) below it; the measured number falls inside the stated range.
By their numbers in this assay, from the lowest: compound 2; then compounds 1 and 3 (each within the scatter of the next).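

In this assay, the substituent on the pyrazole proves to matter in its own right: with the rest of the molecule unchanged, methyl in place of trifluoromethyl gives a step beyond the scatter (a 4.5-fold higher number from compound 2 to compound 3 (0.66 log units; beyond the scatter)), whereas the earlier step had exchanged the whole acyl group. The pyrazole alone does not carry the lower number of compound 2: the step that keeps a pyrazole but bears methyl stays within the scatter (a 1.4-fold higher number from compound 1 to compound 3 (0.15 log units; within the scatter)), so the 3-methyl-1H-pyrazol-5-yl and 1-hydroxy-2,2-dimethylpropyl groups cannot be told apart here.

The compounds shown leave open how a hydrogen, a chlorine atom or a tert-butyl group on this aromatic carbon would stand against methyl and trifluoromethyl. No measurement given here offers an explanation for the step between compound 2 and compound 3.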